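Benzamide variation on a shared thiosulfate sulfurtransferase inhibitor series

The source may hold more compounds than are shown below. What is called first, only, known or untested is meant among the compounds shown, and "the series" means these compounds.

Measured so far:
- compound 1, `COc1c(Br)cc(Br)cc1C(=O)Nc1ccc(Sc2nc3ccccc3s2)c(Cl)c1`: in an assay on isolated protein for inhibition of thiosulfate sulfurtransferase (Homo sapiens), with a stated time of 60 min, in the absence of a further agent (a higher number here means a weaker inhibitor, a lower number a stronger inhibitor), compound 1 gives > 100000 nM, which is a limit of the assay and not a number.
- compound 2, `COc1ccccc1C(=O)Nc1ccc(Sc2nc3ccccc3s2)c(Cl)c1`: in this assay compound 2 gives > 100000 nM, again a limit of the assay.

Compound 2 therefore stands at the limit of > 100000 nM in this assay, at which 2 of the 2 values shown sit, and no measured number places it anywhere within the range the assay can resolve. Among the compounds with values here, the only step between measured compounds, a step that the two limits leave unreadable from compound 1 to compound 2, cannot be read in size or direction, since both ends of it are limits.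

Compound 3, `O=C(Nc1ccc(Sc2nc3ccccc3s2)c(Cl)c1)c1cc(Br)ccc1O`, carries 5-bromo-2-hydroxyphenyl in place of 2-methoxyphenyl on a carbonyl carbon. Within the data shown here, nothing among the measured steps bears on this change in a readable way: the one step available, from compound 1 to compound 2, shows only that neither end reached a measurable value. The expected step of a number no higher from compound 2 to compound 3 (the limit leaves the size open) is accordingly set at none beyond the scatter, pending data. Compound 3 is estimated at 100000 nM, with a range from 30000 nM to 300000 nM, and the likeliest outcome is that the assay again reports only a limit.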

Compound 3, half-maximal inhibitory concentration: > 100000 nM
Compound 3 ended at the assay's limit (the forecaster's own chance of this, stated with the estimate: 75%); the middle value sits exactly at the limit.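

No new step can be read: the steps linking compound 1, compound 2 and compound 3 have a limit of the assay at both ends, and all three compounds stand at that same limit: the limit of > 100000 nM in this assay, at which 3 of the 3 values shown sit.

As far as these compounds go, whether any benzamide variation on the shared core reaches a measurable value in this assay remains open.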